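Ester aryl variation and Vero cytotoxicity in the series

The compounds below may be only part of what the source reports. "The series", "measured", "known", "first", "only" and "open" are said of these compounds alone.

Measured so far:
compound 1 `O=C(OC1CCC(CN2CCN(c3cc(=O)c4cc(C(F)(F)F)cc([N+](=O)[O-])c4s3)CC2)CC1)c1ccco1`: > 64 ug/mL
compound 2 `O=C(OC1CCC(CN2CCN(c3cc(=O)c4cc(C(F)(F)F)cc([N+](=O)[O-])c4s3)CC2)CC1)c1ccncc1`: > 64 ug/mL

In an ADME assay on Vero cells (Chlorocebus sabaeus) for cytotoxicity, read by MTT assay, with a stated time of 48 h (on this read-out higher numbers stand for weaker inhibition and lower numbers for stronger inhibition), compound 1 gives > 64 ug/mL, which is a limit of the assay and not a number. Compound 2 gives > 64 ug/mL in this assay, likewise a limit. The step that the two limits leave unreadable from compound 1 to compound 2 is therefore unreadable in either direction. Compound 2 thus stands at the limit of > 64 ug/mL in this assay, at which 2 of the 2 values shown sit, with no numerical value behind it.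

Compound 3 `O=C(OC1CCC(CN2CCN(c3cc(=O)c4cc(C(F)(F)F)cc([N+](=O)[O-])c4s3)CC2)CC1)c1cccc(F)c1` differs from compound 2 by 3-fluorophenyl in place of pyridin-4-yl on a carbonyl carbon. Going by the values given here, the only measured step touching this position, a step that the two limits leave unreadable from compound 1 to compound 2, gives no size, so no direction can be drawn from it. With both values at the limit, no change beyond the scatter is expected; the step that the limit leaves unreadable from compound 2 to compound 3 is estimated as flat. Compound 3 is expected to give 80 ug/mL in this assay, within 32 ug/mL to 250 ug/mL, most probably reported again as a limit.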

Compound 3, half-maximal inhibitory concentration: > 64 ug/mL
Compound 3 was reported as a limit (the forecaster's own chance of this, stated with the estimate: 80%); the middle value is on the limit's open side.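

Compound 3 sits at the same assay limit as compound 1 and compound 2, so no step among these three compounds can be read: the limit of > 64 ug/mL in this assay, at which 3 of the 3 values shown sit. The compounds shown leave open how furan-2-yl, pyridin-4-yl and 3-fluorophenyl would compare in this assay on numerical values.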